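The source may hold more compounds than are shown below. What is called first, only, known or untested is meant among the compounds shown, and "the series" means these compounds.

Measured compounds:
compound 1 `CC(C)CSc1nc(N)nc2c1ncn2/C=C1/CC1(CO)CO` — 60000 nM
compound 2 `CCCCCCCCSc1nc(N)nc2c1ncn2/C=C1/CC1(CO)CO` — 60000 nM

In an ADME assay on CCRF-HSB-2 cells (Homo sapiens) for cytotoxicity, with a stated time of 7 days (on this read-out higher numbers stand for lower toxicity in this test and lower numbers for higher toxicity in this test), compound 1 gives 60000 nM and compound 2 gives 60000 nM. Going by the values given here, compound 1 stands level with compound 2, the only measured neighbour, as the step of no change at the digits printed from compound 1 to compound 2 (within the scatter) shows. Compound 3 `CCCCOc1nc(N)nc2c1ncn2/C=C1/CC1(CO)CO` differs from compound 1 by butoxy in place of isobutylsulfanyl on an aromatic carbon. Among the compounds with values here, the one measured step bears only loosely on this change, and it was flat; no measured step exchanges sulfur for oxygen at this position. Compound 3 is therefore expected to move little, no change at the digits printed from compound 1 to compound 3 (within the scatter). Compound 3 is estimated at 60000 nM, with a range from 30000 nM to 100000 nM.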

Compound 3, half-maximal cytotoxic concentration: > 20000 nM
Compound 3 gave a limit, no number; the forecaster's own chance of this, stated with the estimate: 40%; the middle value lies beyond the limit too.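

In this assay compound 3 gives > 20000 nM, which is a limit and not a number. Its steps from compound 1 and compound 2 cannot be read. The compounds shown leave open whether butoxy in place of isobutylsulfanyl changes the read-out at all.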